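The source may report more compounds than this note shows. Statements on the series, on what has been measured and on what is new or still open speak of the compounds shown alone.

Working notes on the series. Of the compounds shown here, three sharing one core have been measured in a functional assay on AGS cells (Homo sapiens) for antiproliferative activity, read by CCK-8 assay, with a stated time of 72 h; on this read-out higher numbers stand for weaker inhibition and lower numbers for stronger inhibition. Compound 1 `CN1CCN(c2ccn3c(-c4ccc(NC(=O)c5ccc([N+](=O)[O-])o5)cc4)cnc3c2)CC1` gives 2340 nM. Compound 2 `CC1(O)CCN(c2ccn3c(-c4ccc(NC(=O)c5ccc([N+](=O)[O-])o5)cc4)cnc3c2)CC1` gives 1530 nM. Compound 3 `CN1CCCN(c2ccn3c(-c4ccc(NC(=O)c5ccc([N+](=O)[O-])o5)cc4)cnc3c2)CC1` gives 2700 nM. Compound 2 carries the smallest number of the three, yet a 1.5-fold lower number from compound 1 to compound 2 (0.18 log units; within the scatter) and a 1.8-fold higher number from compound 2 to compound 3 (0.25 log units; within the scatter) both fall within the scatter, so no ranking among the three is supported; likewise a 1.2-fold higher number from compound 1 to compound 3 (0.06 log units; within the scatter) is within the scatter.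

Compound 4 `O=C(Nc1ccc(-c2cnc3cc(Cl)ccn23)cc1)c1ccc([N+](=O)[O-])o1` is not yet measured in this assay. The change from compound 2 is chloro in place of 4-hydroxy-4-methylpiperidin-1-yl on an aromatic carbon. The measured steps that bear on this position, from compound 1 to compound 2 and from compound 2 to compound 3, exchanged one ring-bearing amine substituent for another and each stayed within the scatter. None of them exchanged such a substituent for a single halogen, so the data give no direct guide for this step.

Among the compounds with values here, with no measured step showing an effect at this position, compound 4 is expected to give 2000 nM, within a range of 600 nM to 7000 nM. The estimated step is therefore a 1.3-fold higher number from compound 2 to compound 4 (0.12 log units; within the scatter), a wide band around no change.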

Compound 4, half-maximal inhibitory concentration: 1700 nM
For compound 4 the middle estimate is 1.2-fold (0.07 log units) above the measured one, within the range that was stated.
By their numbers in this assay, from the lowest: compounds 2, 4, 1 and 3 (each within the scatter of the next).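

Within the data shown here, on the position opposite the ring nitrogen, the earlier steps only exchanged one ring-bearing amine for another, whereas this step removes the ring altogether. In this assay, the single chlorine atom replacing 4-hydroxy-4-methylpiperidin-1-yl, with its 8 heavy atoms and hydrogen-bond donor, stays within the scatter (a 1.1-fold higher number from compound 2 to compound 4 (0.05 log units; within the scatter)). The same holds for chloro against the other two amines (a 1.6-fold lower number from compound 3 to compound 4 (0.20 log units; within the scatter); a 1.4-fold lower number from compound 1 to compound 4 (0.14 log units; within the scatter)), so among these four compounds neither the ring nor the hydrogen-bond donor is needed to stay within the scatter.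

No supporting measurement explains this tolerance. Open, as far as these compounds go, is whether a methoxy group, a carboxylic acid or a longer alkyl chain at this position would also stay within the scatter of chloro.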